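The compounds below may be only part of what the source reports. "The series", "measured", "known", "first", "only" and "open" are said of these compounds alone.

Compound 1 `CCCC(=O)OCSc1ccccc1C(=O)NCCC(N)=O` gives > 100 uM in an ADME assay on CEM-SS cells (Homo sapiens) for cytotoxicity, read by XTT assay, with a stated time of 6 days (a lower number here means that less compound is tolerated, a higher number that more compound is tolerated), as its reading, which is a limit of the assay and not a number. Compound 2 `NC(=O)CCNC(=O)c1cccc(S)c1` gives > 100 uM as its reading, again a limit. Compound 3 `CCCC(=O)OCSc1ccc(OC)cc1C(=O)NCCC(N)=O` gives > 100 uM as its reading, also a limit. All three therefore stand together at the limit of > 100 uM in this assay, at which 3 of the 3 values shown sit, and compound 1 has no exact place on the scale.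

The next compound is compound 4 `CCCC(=O)OCSc1ccccc1C(=O)NC1(C(N)=O)CCCC1` where the change is 1-carbamoylcyclopentyl in place of 2-carbamoylethyl on an amide-type nitrogen with 1-carbamoylcyclopentyl in place of 2-carbamoylethyl on an amide-type nitrogen. Among the compounds with values here, only one measured step is available for comparison. That step is a step that the two limits leave unreadable from compound 1 to compound 3 and it is a different change, methoxy in place of hydrogen on an aromatic carbon, so it offers only weak guidance. Within the data shown here, no measured compound shows what a change on the amide-type nitrogen does.

The expectation rests on compound 1 with > 100 uM as its limit and on the matching limits of the other two compounds. No step beyond the scatter is expected, in either direction, so the estimated a number no higher from compound 1 to compound 4 (the limit leaves the size open) is a cautious figure. For compound 4 the estimated value is 100 uM within a range from 40 uM to 250 uM as the expected reading.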

Compound 4, half-maximal toxic concentration: > 100 uM
Compound 4 was reported as a limit; the forecaster's own chance of this, stated with the estimate: 75%; the middle value sits exactly at the limit.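

Within the data shown here, compound 1 and compound 4 both read as a limit of the assay and not as a number, so no step between them can be read: the limit of > 100 uM in this assay, at which 4 of the 4 values shown sit. The compounds shown leave open what concentration is half-maximally toxic for any of them in this assay, and so whether 1-carbamoylcyclopentyl in place of 2-carbamoylethyl changes that concentration at all.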